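This account rests on a few compounds, and the source may have more. Where it says the series, first, only, none or still open, it means among the compounds named here.

Measured compounds: compound 1 `N=C(N)c1cccc(-c2cc3cc(C(=N)N)ccc3o2)c1` with 21200 nM in an ADME assay on L6 cells (Rattus norvegicus) for cytotoxicity; on this read-out higher numbers stand for weaker inhibition and lower numbers for stronger inhibition; compound 2 `N=C(N)c1cccc(-c2cc3ccc(C(=N)N)cc3o2)c1` with 131000 nM; compound 3 `COc1ccc(C(=N)N)cc1-c1cc2cc(C(=N)N)ccc2o1` with 179000 nM.

Compounds 1 and 2 share the same atoms joined differently; the difference between the two cores is not broken down here. Compound 3 carries the change methoxy in place of hydrogen on an aromatic carbon on the core of compound 1, and this gave an 8.4-fold higher number from compound 1 to compound 3 (0.93 log units; beyond the scatter). Compound 2 stands second highest of the three numbers, within the scatter of compound 3 and beyond it from compound 1.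

Compound 4 `COc1ccc(C(=N)N)cc1-c1cc2ccc(C(=N)N)cc2o1` is the unmeasured partner: it carries methoxy in place of hydrogen on an aromatic carbon on the core of compound 2, the same change that led from compound 1 to compound 3, since the two place descriptions agree word for word. If the change behaves as it did once before, compound 4 is expected to show a step of about a 2.7-fold higher number from compound 2 to compound 4 (0.43 log units; beyond the scatter) in this assay, resting on the single earlier step of an 8.4-fold higher number from compound 1 to compound 3 (0.93 log units; beyond the scatter). Compound 4 is therefore estimated at 350000 nM, with a range from 130000 nM to 1000000 nM; a single precedent leaves this wide.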

Compound 4, half-maximal inhibitory concentration: 128000 nM
Compound 4: middle estimate off by 2.7-fold (0.44 log units), on the high side; measured number outside the range, below it.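

In this assay, methoxy in place of hydrogen on an aromatic carbon gave a 1.0-fold lower number from compound 2 to compound 4 (0.01 log units; within the scatter), so on the core of compound 2 this change left the number within the scatter. The same change had a step beyond the scatter on the core of compound 1, and the two results do not agree: the same change on two cores in this assay, an 8.4-fold higher number (0.93 log units; beyond the scatter) from compound 1 to compound 3 and a 1.0-fold lower number (0.01 log units; within the scatter) from compound 2 to compound 4, 8.6-fold (0.94 log units) apart, beyond the scatter of two such steps. For the compounds shown here, this shows that, in this series, the size of the step seen on one core cannot simply be carried to the other, but with only two pairs it does not show which difference between the cores goes with the different outcomes, nor how the change would behave on any further core.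

The compounds shown leave open whether a hydroxyl, an ethoxy or a chlorine in place of the same hydrogen would also give different steps on the two cores. They also leave open whether methoxy on another carbon of that ring would separate the two cores in the same way.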